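This account rests on a few compounds, and the source may have more. Where it says the series, first, only, none or still open, it means among the compounds named here.

Compound 3 `CN1C(=S)[C@@H](NC(=O)c2nc(Cc3ccccc3)n(CCCCC#N)n2)COc2ccccc21` is one of three measured analogues built on a shared core. In a toxicity assay on HT-29 cells (Homo sapiens) for cytotoxicity (a lower number here means that less compound is tolerated, a higher number that more compound is tolerated), compound 3 reaches only a limit, > 100000 nM. Compound 1 `CN1C(=S)[C@@H](NC(=O)c2n[nH]c(Cc3ccccc3)n2)COc2ccccc21` likewise gives only a limit in this assay, > 50000 nM. Compound 2 `CC(C)Cn1nc(C(=O)N[C@H]2COc3ccccc3N(C)C2=S)nc1Cc1ccccc1` again returns only a limit in this assay, > 100000 nM. Accordingly the step that the two limits leave unreadable from compound 1 to compound 2 and the step that the two limits leave unreadable from compound 1 to compound 3 cannot be sized, and the same holds for a step that the two limits leave unreadable from compound 2 to compound 3, the step at the place where compound 4 will differ; both the limit of > 100000 nM in this assay, at which 2 of the 3 values shown sit, and the limit of > 50000 nM in this assay, at which 1 of the 3 values shown sits, say only that the compounds were tolerated up to the top of the tested range.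

Compound 4 `CN1C(=S)[C@@H](NC(=O)c2nc(Cc3ccccc3)n(CC3CCOC3)n2)COc2ccccc21` differs from compound 3 as follows: oxolan-3-yl in place of 3-cyanopropyl on a saturated chain carbon bound to an aromatic nitrogen. Going by the values given here, the one measured step at this place, from compound 2 to compound 3, gave no readable size, so nothing points to a change beyond the scatter. For compound 4 the value in this assay is estimated at 100000 nM, within a range from 30000 nM to 300000 nM, most likely again as a limit. The expected step is a number no higher from compound 3 to compound 4 (the limit leaves the size open).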

Compound 4, half-maximal cytotoxic concentration: > 100000 nM
Compound 4: only a limit was reported; the forecaster's own chance of this, stated with the estimate: 85%; the middle value sits exactly at the limit.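

In this assay compound 4 gives only a limit, > 100000 nM, and none of its steps from compound 1, compound 2 or compound 3 can be read. The compounds shown leave open at what concentration any of the four turns cytotoxic, and whether the groups on the aromatic nitrogen differ at all in this respect.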